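Dimethylamino for methylsulfanyl on a shared nucleoside core

The source may hold more compounds than are shown below. What is called first, only, known or untested is meant among the compounds shown, and "the series" means these compounds.

Compound 2 `CSc1nc(SC)c2ncn([C@@H]3C[C@@H](O)[C@H](CO)O3)c2n1` reaches only the limit of a functional assay on HL-60 cells (Homo sapiens) (on this read-out higher numbers stand for weaker inhibition and lower numbers for stronger inhibition), and gives > 300 uM there, a limit and not a number. Compound 1 `CN(C)c1nc(N)c2ncn([C@@H]3C[C@@H](O)[C@H](CO)O3)c2n1` also gives a limit, > 300 uM, in this assay. Compound 3 `Nc1nc(Br)nc2c1ncn2[C@@H]1C[C@@H](O)[C@H](CO)O1` gives 41 uM in this assay, and the step of an at least 7.3-fold lower number from compound 1 to compound 3 (0.86 log units; beyond the scatter) is the only measured one. Compound 4 `CSc1nc(N(C)C)c2ncn([C@@H]3C[C@@H](O)[C@H](CO)O3)c2n1` carries the change (dimethylamino in place of methylsulfanyl on an aromatic carbon). For the measured compounds named here, no measured step follows this exact change; the one step measured runs in the other direction and swaps a different group. Because the limit of > 300 uM in this assay, at which 2 of the 3 values shown sit, covers both compounds bearing dimethylamino or methylsulfanyl, the expected outcome for compound 4 is another limit, a step that the limit leaves unreadable from compound 2 to compound 4 that is not expected to leave the scatter. The estimate for compound 4 is 400 uM, within 150 uM to 1000 uM.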

Compound 4, concentration for 50% inhibition: > 300 uM
Compound 4 ended at the assay's limit; the forecaster's own chance of this, stated with the estimate: 80%; the middle value lies beyond the limit too.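

Compound 4 gives > 300 uM, a limit and not a number. For the compounds shown here, compound 2 also sits at a limit, so no step between compound 2 and compound 4 can be read. The compounds shown leave open whether dimethylamino in place of methylsulfanyl changes inhibition in this assay at all.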